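A Methoxy Group Added to a Phenyl Tail

The source may report more compounds than this note shows. Statements on the series, on what has been measured and on what is new or still open speak of the compounds shown alone.

Two compounds share a core carrying an amide-linked chain that ends in a phenyl group. Compound 1, `O=C(CCCc1ccccc1)Nc1nc2ccsc2c(=O)s1`, has no reported result in an assay on CHO cells for displacement of a labelled ligand from adenosine receptor A1 (Homo sapiens), read by scintillation counting, with a stated time of 90 min; a lower number here means a stronger inhibitor, a higher number a weaker inhibitor: for compound 1 the entry reads "not determined" (no result reported). Within the data shown here, compound 2, `O=C(CCc1ccccc1)Nc1nc2ccccc2c(=O)s1`, is the only one with a number: in this assay compound 2 gives 1050 nM, so it is the sole point of reference here. Compound 3, `COc1cccc(CCC(=O)Nc2nc3ccccc3c(=O)s2)c1`, is not yet measured. It differs from compound 2 by methoxy in place of hydrogen on an aromatic carbon. Among the measured compounds shown here, no pair of measured compounds differing in one place is available, so nothing here shows how such a change has moved the numbers before. Without that guide, the expectation is that the change from compound 2 to compound 3 stays small, plausibly within the ordinary scatter, in either direction. The estimate for compound 3 in this assay is therefore 900 nM, with a range from 400 nM to 2500 nM. The step that this estimate means is expected to be a 1.2-fold lower number from compound 2 to compound 3 (0.07 log units; within the scatter).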

Compound 3, inhibition constant: 1370 nM
The estimate for compound 3 lay 1.5-fold (0.18 log units) below the measured number; measured number inside the range.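

Putting methoxy in place of hydrogen on an aromatic carbon of the phenyl tail gives, in this assay, a 1.3-fold higher number from compound 2 to compound 3 (0.12 log units; within the scatter). Among these compounds, this is the only measured pair here that differs in one place, and it shows that this position, meta to a large group, can carry a methoxy group while the number stays within what repeated measurements would give, so the two compounds cannot be told apart in this assay. Nothing shown bears on why the step is this size, and no reason for it can be offered from these data.

The compounds shown leave open whether other groups at the same place, such as an amine, a carboxylic acid or a hydroxyl group, would give a step beyond the scatter, and whether methoxy on another carbon of the same ring would read the same. Also open, from the compounds shown here alone, is how a longer chain between the amide and the phenyl group would read on the core of compound 2, and whether methoxy would give a similar step on such a chain.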